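The source may hold more compounds than are shown below. What is called first, only, known or untested is meant among the compounds shown, and "the series" means these compounds.

Working notes on the series. The shared core of compound 2 `COc1cc2c(Oc3ccc(NC(=O)c4nnn(-c5ccccc5C)c4C)cc3F)ccnc2cc1OCCCN1CCCCC1` gives 160 nM in a functional assay on MKN-45 cells (Homo sapiens) for cytotoxicity, read by MTT assay, with a stated time of 72 h; a lower number here means a stronger inhibitor, a higher number a weaker inhibitor. Compound 1 `COc1cc2c(Oc3ccc(NC(=O)c4nnn(-c5ccccc5C)c4C)cc3F)ccnc2cc1OCCCN1CCCC1` gives 270 nM in this assay, and compound 3 `COc1cc2c(Oc3ccc(NC(=O)c4nnn(-c5ccccc5)c4C)cc3F)ccnc2cc1OCCCN1CCCCC1` gives 80 nM. Compound 2 sits between its two neighbours, and both steps to it fall within the scatter: a 1.7-fold lower number from compound 1 to compound 2 (0.23 log units; within the scatter) and a 2.0-fold lower number from compound 2 to compound 3 (0.30 log units; within the scatter). Among the compounds with values here, no measured compound is separated from another beyond the scatter.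

Compound 4 `COc1cc2c(Oc3ccc(NC(=O)c4nnn(-c5ccccc5C)c4C)cc3F)ccnc2cc1OCCCN1CCC(C)CC1` differs from compound 2 in one place: methyl in place of hydrogen on a saturated ring carbon. Within the data shown here, the only measured step at the saturated amine ring is a 1.7-fold lower number from compound 1 to compound 2 (0.23 log units; within the scatter), an exchange of the whole ring that moved the number within the scatter. Among the measured compounds shown here, there is no measured step adding a methyl on a saturated ring carbon, so the expectation rests on that one ring change alone. A step of no more than the scatter is expected in this assay, with no direction to be claimed, i.e. no change at the digits printed from compound 2 to compound 4 (within the scatter) is expected. Compound 4 is therefore estimated at 160 nM, within a range from 80 nM to 320 nM.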

Compound 4, half-maximal inhibitory concentration: 120 nM
The estimate for compound 4 lay 1.3-fold (0.12 log units) above the measured number; the range from low to high includes it.
By their numbers in this assay, from the lowest: compounds 3, 4, 2 and 1 (each within the scatter of the next, the first and the last beyond it).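

In this assay, a methyl on the saturated ring carbon three ring bonds from the ring nitrogen leaves the number within the scatter, a 1.3-fold lower number from compound 2 to compound 4 (0.12 log units; within the scatter), so 4-methylpiperidin-1-yl and piperidin-1-yl cannot be told apart here. Exchange of the whole ring now goes beyond the scatter, though only modestly, a 2.3-fold lower number from compound 1 to compound 4 (0.35 log units; beyond the scatter), whereas the exchange to the unsubstituted piperidin-1-yl stayed within it, a 1.7-fold lower number from compound 1 to compound 2 (0.23 log units; within the scatter). Nothing available explains either step.

Going by these compounds, it remains open whether a hydroxyl or a longer chain such as propyl on this same ring carbon, or a second ring nitrogen carrying a methyl, would keep the number in this range. On these data alone, it is also open whether the 4-methylpiperidin-1-yl group gives a similar step on the core of compound 3.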